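From Phenyl to Furan on the Exocyclic Carbon

The source may report more compounds than this note shows. Statements on the series, on what has been measured and on what is new or still open speak of the compounds shown alone.

Compound 1 `COc1cc(C=C2C(=O)N(c3ccc(Cl)cc3)N(c3ccc(Cl)cc3)C2=O)ccc1O` was tested in a functional assay on MCF7 cells (Homo sapiens) for cytotoxicity, read by MTT assay, with a stated time of 72 h (on this read-out lower numbers stand for stronger inhibition and higher numbers for weaker inhibition), where compound 1 gives 22800 nM. Its closest relative among the measured compounds is compound 2 `COc1ccccc1C=C1C(=O)N(c2ccc(Cl)cc2)N(c2ccc(Cl)cc2)C1=O`, which in this assay gives 26300 nM. Going by the values given here, on these two numbers compound 1 stands lowest, and the only measured step, a 1.2-fold higher number from compound 1 to compound 2 (0.06 log units; within the scatter), shows that exchanging the aryl group at that position left the read-out essentially unchanged. Compound 3 `O=C1C(=Cc2ccco2)C(=O)N(c2ccc(Cl)cc2)N1c1ccc(Cl)cc1` is not yet measured. It differs from compound 1 by furan-2-yl in place of 4-hydroxy-3-methoxyphenyl on a double-bonded chain carbon bound to a double-bonded ring carbon. Among the compounds with values here, the one step that bears on this change is the step from compound 1 to compound 2, since it also replaced the group on the double-bonded chain carbon, and it stayed within the scatter. Within the data shown here, no other step is available, so the expectation for compound 3 rests on that single comparison. Compound 3 is therefore expected to show no step beyond the scatter, an expected 1.1-fold higher number from compound 1 to compound 3 (0.04 log units; within the scatter). In this assay compound 3 is estimated to give 25000 nM, with a likely range from 8000 nM to 80000 nM.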

Compound 3, half-maximal inhibitory concentration: 20300 nM
Estimate against measurement, compound 3: 1.2-fold (0.09 log units) above; the measured number falls inside the stated range.
By their numbers in this assay, from the lowest: compounds 3, 1 and 2 (each within the scatter of the next).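

In this assay, the furan-2-yl group replaces the 4-hydroxy-3-methoxyphenyl group with a 1.1-fold lower number from compound 1 to compound 3 (0.05 log units; within the scatter), and it replaces the 2-methoxyphenyl group with a 1.3-fold lower number from compound 2 to compound 3 (0.11 log units; within the scatter). The earlier pair showed only an exchange between two six-membered aromatic rings of carbon only, whereas this change brings in a five-membered aromatic ring with 1 hetero atom, reduces the group from 9 heavy atoms to 5, and removes the hydrogen-bond donor of compound 1, yet the read-out on the double-bonded chain carbon stays within the scatter across all three compounds. Nothing measured here accounts for this flat result.

Going by these compounds, all three groups at this position are aromatic rings, so it remains open whether an amine, a carboxylic acid or a longer chain in that place would move the number beyond the scatter. The rest of the core is the same in all three compounds, which leaves open whether this flat read-out would persist if that core were changed.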